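The source may hold more compounds than are shown below. What is called first, only, known or untested is meant among the compounds shown, and "the series" means these compounds.

Working notes on the series. Compound 1 `CC(C)CCn1nc(-c2cccs2)c(O)c(C2=CS(=O)(=O)c3cc(NS(C)(=O)=O)ccc3N2)c1=O` gives > 1 h in an in vitro ADME assay on microsomes from liver (Homo sapiens) for metabolic stability (a lower number here means that the compound disappears faster, a higher number that the compound lasts longer), and that is a limit of the assay, not a number. Compound 2 `CS(=O)(=O)Nc1ccc2c(c1)S(=O)(=O)C=C(c1c(O)c(-c3cccs3)nn(CC3CC3)c1=O)N2` gives > 1 h in this assay and this too is only a limit. All that can be read so far is the limit of > 1 h in this assay, at which 2 of the 2 values shown sit, and nothing finer. For the measured compounds named here, the one measured step is a step that the two limits leave unreadable from compound 1 to compound 2 for cyclopropyl in place of isobutyl on a saturated chain carbon bound to an aromatic nitrogen, and it offers no size to carry over.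

The change to compound 3 `CC(C)CCn1nc(-c2ccccc2)c(O)c(C2=CS(=O)(=O)c3cc(NS(C)(=O)=O)ccc3N2)c1=O` is phenyl in place of thiophen-2-yl on an aromatic carbon and in words it is phenyl in place of thiophen-2-yl on an aromatic carbon, with the isopentyl group kept. Going by the values given here, no measured step touches this place, so no direction can be read and no shift beyond the scatter is expected. The expected change is a step that the limit leaves unreadable from compound 1 to compound 3 on this estimate. Compound 3 is estimated at 1.5 h in this assay with an expected range from 0.7 h to 4 h and a fair chance of only a limit again.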

Compound 3, half-life: 0.6 h
For compound 3 the middle estimate is 2.5-fold (0.40 log units) above the measured one; measured number below the stated range.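

For the compounds shown here, this is the first step whose direction can be read, and it sits on the aromatic carbon next to the ring nitrogen and ortho to a hydroxy group: in this assay, phenyl in place of thiophen-2-yl gives an at least 1.6-fold lower number from compound 1 to compound 3 (0.22 log units; that floor lies within the scatter). Going by these compounds alone, compound 3, with 0.6 h, is also the first compound to give a number rather than a limit, so the series now has a measured value from which later changes can be read. From the compounds shown here alone, compound 1 gives > 1 h, which is a limit, so only a floor can be read for this step and its full size remains unknown: the limit of > 1 h in this assay, at which 2 of the 3 values shown sit.

The compounds shown leave open how a furan-2-yl or a pyridin-3-yl group on this aromatic carbon would read in this assay, since phenyl is the only replacement for thiophen-2-yl shown here. Going by these compounds, the step for cyclopropyl in place of isobutyl still cannot be read, and it also remains open whether that change would shift the value of compound 3.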